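Swapping the chain on the carbonyl: compound 3 to compound 4

The source may report more compounds than this note shows. Statements on the series, on what has been measured and on what is new or still open speak of the compounds shown alone.

Measured compounds:
compound 1, `CC(C)C[C@H](N)c1cc(C(F)(F)F)ccc1N1CCN(C(=O)COc2ccc(Cl)cc2)CC1`, 2900 nM
compound 2, `Cc1cc(CC(C)C(=O)N2CCN(c3ccc(C(F)(F)F)cc3[C@@H](N)CC(C)C)CC2)ccc1Cl`, 71 nM
compound 3, `Cc1cc(Cl)ccc1CC(C)C(=O)N1CCN(c2ccc(C(F)(F)F)cc2[C@@H](N)CC(C)C)CC1`, 38 nM

In an assay on HEK293 cells for displacement of a labelled ligand from Melanocortin receptor 4 (Homo sapiens) (a higher number here means a weaker inhibitor, a lower number a stronger inhibitor), compound 3 gives the lowest number of the three; compound 2 sits within the scatter of it, while compound 1 is far higher. Compound 4, `CC(C)C[C@H](N)c1cc(C(F)(F)F)ccc1N1CCN(C(=O)CSc2ccc(Cl)cc2Cl)CC1`, differs from compound 3 by ((2,4-dichlorophenyl)sulfanyl)methyl in place of 1-(4-chloro-2-methylbenzyl)ethyl on a carbonyl carbon. For the measured compounds named here, the only steps that bear on this change are a 76-fold lower number from compound 1 to compound 3 (1.88 log units; beyond the scatter) and a 41-fold lower number from compound 1 to compound 2 (1.61 log units; beyond the scatter), both large, and both run from a phenoxymethyl chain on that carbonyl to a benzyl-bearing chain. Compound 4 returns to a heteroatom-linked methyl chain of the kind found in compound 1, though with sulfur and two chlorines instead. The number for compound 4 is therefore expected to rise sharply, with a 26-fold higher number from compound 3 to compound 4 (1.42 log units; beyond the scatter). Compound 4 is estimated at 1000 nM, between 200 nM and 5000 nM.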

Compound 4, inhibition constant: 1500 nM
The estimate for compound 4 lay 1.5-fold (0.18 log units) below the measured number, and the stated range covers the measured number.
By their numbers in this assay, from the lowest: compounds 3 and 2 (each within the scatter of the next); then compounds 4 and 1 (each within the scatter of the next).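

Both benzyl-bearing chains stand well clear of the sulfur-linked chain: ((2,4-dichlorophenyl)sulfanyl)methyl on the carbonyl carbon gives a 39-fold higher number from compound 3 to compound 4 (1.60 log units; beyond the scatter) and a 21-fold higher number from compound 2 to compound 4 (1.32 log units; beyond the scatter) in this assay. Sulfur and the second chlorine do not separate this chain from the oxygen-linked one, with a 1.9-fold lower number from compound 1 to compound 4 (0.29 log units; within the scatter), so across these four compounds the benzyl-bearing chains give the lower numbers and none goes against this. No measurement shown gives a reason for this gap.

As far as these compounds go, the change alters several features of the chain at once, so which of them carries the step remains open. Also open, from the compounds shown here alone, is how a chain ending in an amine or a carboxylic acid would read here.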